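A few compounds are considered here, and "the series" means these few. Any claim that something is new, unique, unknown or untested is made for them only; others in the source may bear on it.

Notes on the series. In a functional assay on CCRF-CEM cells (Homo sapiens) for cytotoxicity, read by cell counting, with a stated time of 3 days (a higher number here means a weaker inhibitor, a lower number a stronger inhibitor), compound 3 `Nc1ccc(/C=C2\SC(=O)N(Cc3ccc(F)cc3)C2=O)cc1` gives 111000 nM, the highest number among the three measured compounds; compound 1 `C=C(Br)C(=O)Nc1ccc(/C=C2\SC(=O)N(Cc3cccc(F)c3)C2=O)cc1` gives 3200 nM and compound 2 `C=C(Br)C(=O)Nc1ccc(/C=C2\SC(=O)N(Cc3ccc(C)cc3)C2=O)cc1` gives 3700 nM, both carrying the same amide that compound 3 lacks. The change to compound 4 `C=C(Br)C(=O)Nc1ccc(/C=C2\SC(=O)N(Cc3ccc(F)cc3)C2=O)cc1` is (1-bromoethenyl)carbonyl in place of hydrogen on a nitrogen on an aromatic ring. Among the compounds with values here, no measured step covers this exact change. Within the data shown here, the only measured step, a 1.2-fold higher number from compound 1 to compound 2 (0.06 log units; within the scatter), shows that the group on the ring nitrogen hardly matters, so compound 4 should sit near compound 1 and compound 2 rather than near compound 3, and a large step downward in this assay is expected, a 33-fold lower number from compound 3 to compound 4 (1.51 log units; beyond the scatter). Compound 4 is therefore estimated at 3400 nM, with a range of 1500 nM to 7500 nM.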

Compound 4, half-maximal inhibitory concentration: 2400 nM
Compound 4: the middle estimate sits 1.4-fold (0.15 log units) above what was measured; low and high end bracket the measured number.
By their numbers in this assay, from the lowest: compounds 4, 1 and 2 (each within the scatter of the next); then compound 3.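

In this assay, the step of a 46-fold lower number from compound 3 to compound 4 (1.67 log units; beyond the scatter) now ties the large gap to (1-bromoethenyl)carbonyl in place of hydrogen on the aromatic nitrogen as a single change. With that group held constant, a 1.5-fold lower number from compound 2 to compound 4 (0.19 log units; within the scatter) for fluoro in place of methyl and a 1.3-fold lower number from compound 1 to compound 4 (0.12 log units; within the scatter) for 4-fluorophenyl in place of 3-fluorophenyl both lie within the scatter, so these three compounds do not separate on the aryl change. Nothing measured here explains the size of the step.

Still open, from the compounds shown here alone, is whether the bromine, the double bond or the carbonyl carries the step; an acetyl or a propenoyl group on that nitrogen would separate them.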